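Phenyl in place of fluoro: an expected shift

The compounds below may be only part of what the source reports. "The series", "measured", "known", "first", "only" and "open" are said of these compounds alone.

Compound 1, `O=C(Nc1nnc(-c2ccc(Cl)cc2)s1)c1ccccc1Br`, in a functional assay on the whole organism (integument) for inhibition, with Chilo suppressalis as the target, read by scintillation counting, with a stated time of 72 h; on this read-out lower numbers stand for stronger inhibition and higher numbers for weaker inhibition: > 5010 nM, which is a limit of the assay and not a number.
Compound 2, `COc1cccc(OC)c1C(=O)Nc1nnc(-c2ccc(F)cc2)s1`, in this assay: 97.7 nM.

Going by the values given here, compound 2 thus holds the only real number among the two measured compounds, the other value being a limit, as the limit of > 5010 nM in this assay, at which 1 of the 2 values shown sits, states. Compound 3, `COc1cccc(OC)c1C(=O)Nc1nnc(-c2ccc(-c3ccccc3)cc2)s1`, has not yet been measured. It differs from compound 2 by a single change, (phenyl in place of fluoro on an aromatic carbon). Among the compounds with values here, no step between measured compounds is available to guide the size of this change, and a single fluoro-to-phenyl exchange on an aromatic carbon cannot be scored from these two compounds alone. With no shown step to rest on, the expectation is a modest weakening beyond the scatter, with a wide spread either way. Compound 3 is therefore expected to give about 250 nM, somewhere between 50 nM and 2000 nM, which is an estimated step of a 2.6-fold higher number from compound 2 to compound 3 (0.41 log units; beyond the scatter).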

Compound 3, half-maximal inhibitory concentration: 195 nM
The estimate for compound 3 lay 1.3-fold (0.11 log units) above the measured number, and the stated range covers the measured number.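

In this assay, putting phenyl in place of fluoro on an aromatic carbon, para to a large group, gives a 2.0-fold higher number from compound 2 to compound 3 (0.30 log units; within the scatter), so the two compounds cannot be told apart on this read-out. This position therefore accepts a whole six-membered aromatic ring of carbon only in place of a single fluorine atom without a change that stands clear of the scatter, something that compound 1 and compound 2 could not show, as they differ in more than one place. Nothing measured here offers a reason for this result.

On these data alone, whether an amine, a carboxylic acid or a longer chain at this position would behave in the same way stays open. One step also cannot show whether the same exchange would do the same on another core.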